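Amino Group Added to a Weak Secondary Amine

A few compounds are considered here, and "the series" means these few. Any claim that something is new, unique, unknown or untested is made for them only; others in the source may bear on it.

Compound 2 `C/C=C/C(=O)N(Cc1ccc(OC)cc1)c1cc(OC)c(OC)c(OC)c1` and compound 1 `C/C=C/C(=O)N(Cc1ccc(OC)c(N)c1)c1cc(OC)c(OC)c(OC)c1` share a core and differ only by amino in place of hydrogen on an aromatic carbon. In a functional assay on HCT-116 cells (Homo sapiens) for inhibition, read by MTT assay, with a stated time of 48 h (on this read-out higher numbers stand for weaker inhibition and lower numbers for stronger inhibition), compound 2 gives 500 nM and compound 1 gives 300 nM, which amounts to a 1.7-fold lower number from compound 2 to compound 1 (0.22 log units; within the scatter). Compound 3 `COc1ccc(CNc2cc(OC)c(OC)c(OC)c2)cc1` has a different core, separated from compound 2 by hydrogen in place of (prop-1-en-1-yl)carbonyl on a nitrogen on an aromatic ring, and in this assay compound 3 gives 18400 nM, a change of a 37-fold higher number from compound 2 to compound 3 (1.57 log units; beyond the scatter). Compound 4 `COc1ccc(CNc2cc(OC)c(OC)c(OC)c2)cc1N` has not yet been measured. It differs from compound 3 by amino in place of hydrogen on an aromatic carbon, the same change that separates compound 2 from compound 1, so the change appears in two pairs among these compounds, at the same place in each. Because the earlier step was a 1.7-fold lower number from compound 2 to compound 1 (0.22 log units; within the scatter), a step of similar small size is expected from compound 3 to compound 4, a 1.5-fold lower number from compound 3 to compound 4 (0.19 log units; within the scatter). That one pair is the only support, so the expectation rests on little. Compound 4 is therefore expected to give about 12000 nM in this assay, with a likely range from 5000 nM to 30000 nM.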

Compound 4, half-maximal inhibitory concentration: 8270 nM
Estimate against measurement, compound 4: 1.5-fold (0.16 log units) above; the measured number falls inside the stated range.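

In this assay, placing the amino group on the core that lacks the (prop-1-en-1-yl)carbonyl group gives a 2.2-fold lower number from compound 3 to compound 4 (0.35 log units; beyond the scatter), and this step matches the one on the other core: the same change on two cores in this assay, a 1.7-fold lower number (0.22 log units; within the scatter) from compound 2 to compound 1 and a 2.2-fold lower number (0.35 log units; beyond the scatter) from compound 3 to compound 4, 1.3-fold (0.13 log units) apart, within the scatter of two such steps. Removing the (prop-1-en-1-yl)carbonyl group in the presence of the amino group gives a 28-fold higher number from compound 1 to compound 4 (1.44 log units; beyond the scatter), and this large loss also carries over from the compounds without the amino group: the same change on two cores in this assay, a 37-fold higher number (1.57 log units; beyond the scatter) from compound 2 to compound 3 and a 28-fold higher number (1.44 log units; beyond the scatter) from compound 1 to compound 4, 1.3-fold (0.13 log units) apart, within the scatter of two such steps. Across these four compounds, each change therefore has about the same size whether or not the other is present, but this rests on just two cores and one place on the ring, so it does not show that the amino step would hold on a third core, nor why either change has the size it has.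

The compounds shown leave open whether a hydroxyl group or a methylamino group in place of the amino group would give a similar step. They also leave open whether a plain acetyl group on the nitrogen could stand in for the (prop-1-en-1-yl)carbonyl group.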